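Vero cell tolerance across a thiosemicarbazone pair

The source may hold more compounds than are shown below. What is called first, only, known or untested is meant among the compounds shown, and "the series" means these compounds.

Measured compounds:
compound 1, `Cc1ccccc1/C=N\NC(=S)N(Cc1ccccc1)Cc1ccccc1`, 167000 nM
compound 2, `C=CCN(CC=C)C(=S)N/N=C(/C)c1ccc(F)cc1`, 214000 nM

Both values come from an ADME assay on Vero cells (Chlorocebus sabaeus) for cytotoxicity, read by MTT assay, with a stated time of 72 h; a higher number here means that more compound is tolerated, a lower number that less compound is tolerated. Compound 1 gives the lower of the two numbers in this assay, but compound 2 lies within the scatter of it, so nothing separates them on tolerance. For the measured compounds named here, no step between measured compounds that differ in one place is available.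

Compound 3, `O=[N+]([O-])c1ccccc1/C=N\NC(=S)N(Cc1ccccc1)Cc1ccccc1`, is not yet measured. It differs from compound 1 as follows: nitro in place of methyl on an aromatic carbon

With no measured step of this kind in the set, the expectation rests on the two values alone, which sit close together. The step in this assay a 1.1-fold lower number from compound 1 to compound 3 (0.05 log units; within the scatter) is expected to stay within the scatter, in no particular direction. Compound 3 is therefore estimated at 150000 nM, with a range from 60000 nM to 350000 nM.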

Compound 3, half-maximal cytotoxic concentration: < 155000 nM
Compound 3: no number, only a limit; the forecaster's own chance of this, stated with the estimate: 20%; the middle value does not contradict the limit.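

In this assay compound 3 gives < 155000 nM, which is a limit of the assay and not a number. Going from 2-methylphenyl to 2-nitrophenyl, on an aromatic carbon ortho to a large group, gives an at least 1.0-fold lower number from compound 1 to compound 3 (0.03 log units; that floor lies within the scatter), so this position accepts the nitro swap without any step that can be read beyond the scatter, though the limit leaves the true size of the step undefined. The only firm statement on this change therefore rests on the limit itself: the limit of < 155000 nM in this assay, at which 1 of the 3 values shown sits.

How far the value of compound 3 lies from that limit remains open, and a real separation from compound 1 can be neither shown nor excluded. Also open, from the compounds shown here alone, is what an amine or a carboxylic acid on this aromatic carbon would give in this assay.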